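This account rests on a few compounds, and the source may have more. Where it says the series, first, only, none or still open, it means among the compounds named here.

Measured compounds:
compound 1 `CC#C[C@@H](Cc1nnn[nH]1)c1ccc(OCc2ccc3scc(C4CCCCC4)c3c2)cc1` with 16 nM in a functional assay on cells for agonist activity at Free fatty acid receptor 1 (Rattus norvegicus), read by FLIPR and calcium flux; on this read-out higher numbers stand for an effect only at larger amounts of compound and lower numbers for an effect already at smaller amounts
compound 2 `CC#C[C@@H](Cc1nnn[nH]1)c1ccc(OCc2ccc3scc(-c4cncnc4C)c3c2)cc1` with 18 nM in this assay

Within the data shown here, of the two numbers in hand, compound 2 holds the higher one, but its only neighbour is compound 1, and the step of a 1.1-fold higher number from compound 1 to compound 2 (0.05 log units; within the scatter) lies within the scatter, so the two compounds cannot be told apart on this read-out. Compound 3 `CC#C[C@@H](Cc1nnn[nH]1)c1ccc(OCc2ccc3scc(C4CC4)c3c2)cc1` is not yet measured. It differs from compound 2 in one place: cyclopropyl in place of 4-methylpyrimidin-5-yl on an aromatic carbon. Among the measured compounds shown here, the one measured step that bears on this position, a 1.1-fold higher number from compound 1 to compound 2 (0.05 log units; within the scatter), exchanged one ring substituent for another on the same aromatic carbon and left the number essentially unchanged. For the measured compounds named here, the cyclopropyl group is a third ring substituent at that carbon, smaller than either of the two already seen, and no measured compound shows how a group of that size behaves there. The expectation is therefore a step of a 1.4-fold higher number from compound 2 to compound 3 (0.14 log units; within the scatter) from compound 2 to compound 3, most likely within the scatter, with the range left wide for the untested group. For compound 3 the estimate in this assay is 25 nM, between 8 nM and 80 nM.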

Compound 3, half-maximal effective concentration: 239 nM
Estimate against measurement, compound 3: 9.6-fold (0.98 log units) below; the whole stated range lies below it.
By their numbers in this assay, from the lowest: compounds 1 and 2 (each within the scatter of the next); then compound 3.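

In this assay the group on this aromatic carbon of the five-membered ring proves not to be indifferent: putting cyclopropyl in place of 4-methylpyrimidin-5-yl gives a 13-fold higher number from compound 2 to compound 3 (1.12 log units; beyond the scatter) and putting it in place of cyclohexyl gives a 15-fold higher number from compound 1 to compound 3 (1.17 log units; beyond the scatter) as well, both large steps beyond the scatter. The earlier pair suggested tolerance at this carbon, since cyclohexyl and 4-methylpyrimidin-5-yl could not be told apart despite being very different rings, but that tolerance does not extend to the three-membered ring of carbon only, which is the smallest of the three groups and needs larger amounts of compound for its effect. Nothing in the available data accounts for this loss.

With only three groups at this carbon, the compounds shown leave open whether the number depends on the size of the group, and cyclobutyl, cyclopentyl or phenyl there would show whether it changes gradually or abruptly. They also leave open how an open chain such as isopropyl or tert-butyl would compare, and what plain hydrogen on this carbon would give.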